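Will a chloro group shift compound 1?

The source may report more compounds than this note shows. Statements on the series, on what has been measured and on what is new or still open speak of the compounds shown alone.

In a functional assay on RAW264.7 cells (Mus musculus) for inhibition (on this read-out lower numbers stand for stronger inhibition and higher numbers for weaker inhibition), compound 1 (`O=C1/C(=C/c2ccccc2)CCc2ccc(O)cc21`) gives 710 nM. Compound 2 (`O=C1/C(=C/c2cccc(F)c2)CCc2ccc(O)cc21`) gives 830 nM, and compound 3 (`O=C1/C(=C/c2ccc(OC(F)(F)F)cc2)CCc2ccc(O)cc21`) gives 980 nM. These three values all lie within the scatter of one another, so compound 1 cannot be told apart from the other two on these numbers.

Compound 4 (`O=C1/C(=C/c2ccccc2Cl)CCc2ccc(O)cc21`) has not been measured yet. It is compound 1 with chloro in place of hydrogen on an aromatic carbon, ortho to a large group (chloro in place of hydrogen on an aromatic carbon).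

Among the measured compounds shown here, two measured steps bear on this change, as each also swaps a hydrogen on an aromatic carbon for a new group. Fluoro gives a 1.2-fold higher number from compound 1 to compound 2 (0.07 log units; within the scatter), and trifluoromethoxy gives a 1.4-fold higher number from compound 1 to compound 3 (0.14 log units; within the scatter). Neither step involves chloro or that same place, so they offer only a loose guide.

Going by those two steps, no change beyond the scatter is expected, and the estimated step is a 1.1-fold higher number from compound 1 to compound 4 (0.05 log units; within the scatter). Compound 4 is expected to give about 800 nM, with an estimated range from 350 nM to 1800 nM.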

Compound 4, half-maximal inhibitory concentration: 270 nM
Beside the measured number, compound 4's estimate is 3.0-fold (0.47 log units) above it; measured number below the stated range.
By their numbers in this assay, from the lowest: compound 4; then compounds 1, 2 and 3 (each within the scatter of the next).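

In this assay, chloro in place of hydrogen on an aromatic carbon, ortho to a large group, gives a 2.6-fold lower number from compound 1 to compound 4 (0.42 log units; beyond the scatter): a modest step, but one that clears the scatter. The earlier changes at other places on this ring, a 1.2-fold higher number from compound 1 to compound 2 (0.07 log units; within the scatter) and a 1.4-fold higher number from compound 1 to compound 3 (0.14 log units; within the scatter), stayed within the scatter, so this is the first single swap shown here that clearly moves the number, and the move is towards stronger inhibition. Nothing available explains why this step differs from the other two.

From the compounds shown here alone, it remains open whether the lower number belongs to chloro itself or to this place on the ring, which chloro at another place on the ring could help to separate. A bromo, a methyl or an amine at this same place could also show how much the group's identity matters here.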